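Urea-to-amide change on the shared core: expected cytotoxicity

A few compounds are considered here, and "the series" means these few. Any claim that something is new, unique, unknown or untested is made for them only; others in the source may bear on it.

Two analogues of the shared core have been measured so far. In a functional assay on NCI-H322M cells (Homo sapiens) for inhibition, read by sulforhodamine B assay, with a stated time of 48 h (on this read-out higher numbers stand for lower toxicity in this test and lower numbers for higher toxicity in this test), compound 1 `COc1cc(-c2nn(-c3cccc(NC(=O)Nc4ccc(Cl)c(Cl)c4)c3)cc2-c2ccncc2)ccc1Cl` reaches only the limit of the assay and gives > 50000 nM, which is a limit and not a number. Compound 2 `O=C(Nc1cccc(-n2cc(-c3ccncc3)c(-c3ccc(Cl)c(O)c3)n2)c1)Nc1cc(C(F)(F)F)cc(C(F)(F)F)c1`, which carries a different substituted phenyl on the urea and a hydroxyl in place of the methoxy group, gives in this assay 23600 nM. Within the data shown here, the limit is the only evidence on compound 1: the limit of > 50000 nM in this assay, at which 1 of the 2 values shown sits. Compound 3 `COc1cc(-c2nn(-c3cccc(NC(=O)c4ccccc4)c3)cc2-c2ccncc2)ccc1Cl` is not yet measured in this assay. It differs from compound 1 as follows: phenyl in place of (3,4-dichlorophenyl)amino on a carbonyl carbon, so the urea of compound 1 becomes a benzamide. Among the measured compounds shown here, no pair of measured compounds differing in one place is available, so the size of the step cannot be read from the data. Compound 3 is expected to stay in the weakly toxic range, a step of an at least 1.2-fold lower number from compound 1 to compound 3 (0.09 log units; that floor lies within the scatter) of no more than the scatter or a modest move to a lower number. The estimate for compound 3 in this assay is 40000 nM, with a range from 15000 nM to 50000 nM, and a limit remains plausible.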

Compound 3, concentration lethal to 50% of the cells: > 100000 nM
Compound 3 ended at the assay's limit (the forecaster's own chance of this, stated with the estimate: 50%); middle value at least 2.5-fold (0.39 log units) away from the limit.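

In this assay compound 3 gives > 100000 nM, which is a limit and not a number. Among these compounds, compound 1 gives > 50000 nM, also a limit, so no step between compound 1 and compound 3 can be read. The compounds shown leave open how far phenyl in place of (3,4-dichlorophenyl)amino on the carbonyl carbon moves this read-out.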